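A few compounds are considered here, and "the series" means these few. Any claim that something is new, unique, unknown or untested is made for them only; others in the source may bear on it.

Compound 1 `CC(C)c1c(C(=O)N2CCC[C@H](N3CCC4C=CC=CC4C3)C2)nn(-c2ccc(F)cc2)c1CC[C@@H](O)C[C@@H](O)CC(=O)O` gives 10 nM in an assay on microsomes from liver for inhibition of 3-hydroxy-3-methylglutaryl-coenzyme A reductase (Rattus norvegicus); on this read-out higher numbers stand for weaker inhibition and lower numbers for stronger inhibition. Compound 2 `Cc1cccc(CNC(=O)c2nn(-c3ccc(F)cc3)c(OC[C@@H](O)C[C@@H](O)CC(=O)O)c2C(C)C)c1` gives 4.9 nM in this assay.

Among the compounds with values here, of these two numbers, compound 2 has the lower one, and compound 1 with its higher value is its only neighbour; the gap between them lies beyond the usual scatter of this assay. Nothing else among the measured compounds tells how a single change at the benzyl amide end shifts potency.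

Compound 3 `COc1ccccc1CNC(=O)c1nn(-c2ccc(F)cc2)c(OC[C@@H](O)C[C@@H](O)CC(=O)O)c1C(C)C` differs from compound 2 in one place: 2-methoxyphenyl in place of 3-methylphenyl on a saturated chain carbon bound to an amide-type nitrogen. The rest of the molecule, including the fluorophenyl group on the core and the dihydroxy acid chain, is kept. Within the data shown here, no measured pair shows this exact exchange, so the expectation rests on compound 2 alone, whose value of 4.9 nM sets the starting point. The step of a 1.2-fold higher number from compound 2 to compound 3 (0.09 log units; within the scatter) is expected to stay within the scatter, with no clear direction. Compound 3 is therefore estimated at 6 nM in this assay, in a range from 2.5 nM to 15 nM.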

Compound 3, half-maximal inhibitory concentration: 22 nM
Compound 3: the middle estimate sits 3.7-fold (0.56 log units) below what was measured, and the stated range ends below it.
By their numbers in this assay, from the lowest: compound 2; then compound 1; then compound 3.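

In this assay the exchange of 3-methylphenyl for 2-methoxyphenyl on a saturated chain carbon bound to an amide-type nitrogen gives a 4.5-fold higher number from compound 2 to compound 3 (0.65 log units; beyond the scatter) and thus weaker inhibition, which shows that this position is not indifferent to the group it carries. Within the data shown here, since the fluorophenyl group, the core and the dihydroxy acid chain are kept, this loss belongs to the single exchange, and the earlier compounds, which differ in more than one place, could not isolate such an effect. The entering group adds an oxygen and a hydrogen-bond acceptor to the benzyl end, but nothing available accounts for the shift in potency.

The exchange alters both the substituent and its printed ring number at once, so the compounds shown cannot separate the two changes; 2-methylphenyl and 3-methoxyphenyl would each alter only one of them. On these data alone, it also remains open whether an unsubstituted phenyl or a 3-chlorophenyl group at this position would fall nearer to compound 2 or to compound 3.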